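Swapping tert-Butyl for 1-Hydroxyethyl in Compound 2

The source may hold more compounds than are shown below. What is called first, only, known or untested is meant among the compounds shown, and "the series" means these compounds.

Of the compounds shown here, three sharing one core have been measured in an assay on isolated protein for inhibition of Indoleamine 2,3-dioxygenase 2 (Homo sapiens); a higher number here means a weaker inhibitor, a lower number a stronger inhibitor. Compound 1 `CCCCc1cn(CCNc2nonc2/C(=N/O)Nc2ccc(F)c(Br)c2)nn1` gives 830 nM, compound 2 `CC(C)(C)c1cn(CCNc2nonc2/C(=N/O)Nc2ccc(F)c(Br)c2)nn1` gives 1870 nM, and compound 3 `OCCCCc1cn(CCNc2nonc2/C(=N/O)Nc2ccc(F)c(Br)c2)nn1` gives 1080 nM. Compound 2 sits at the upper end of these numbers: the step of a 2.3-fold higher number from compound 1 to compound 2 (0.35 log units; beyond the scatter) lies beyond the scatter, while the step of a 1.7-fold lower number from compound 2 to compound 3 (0.24 log units; within the scatter) stays within it, so compound 2 and compound 3 cannot be told apart. Compound 4 `CC(O)c1cn(CCNc2nonc2/C(=N/O)Nc2ccc(F)c(Br)c2)nn1` differs from compound 2 by 1-hydroxyethyl in place of tert-butyl on an aromatic carbon. Both measured steps leaving tert-butyl point to a weak lowering at most. For compound 4 a step of a 1.6-fold lower number from compound 2 to compound 4 (0.19 log units; within the scatter) in this assay is therefore expected, a small drop near the edge of the scatter. Compound 4 is estimated at 1200 nM, within the range 550 nM to 2600 nM.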

Compound 4, half-maximal inhibitory concentration: 362 nM
For compound 4 the middle estimate is 3.3-fold (0.52 log units) above the measured one; the whole stated range lies above it.
By their numbers in this assay, from the lowest: compound 4; then compounds 1, 3 and 2 (each within the scatter of the next, the first and the last beyond it).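

In this assay, going by these compounds alone, the group on this aromatic carbon matters more than the earlier compounds showed: 1-hydroxyethyl gives a 5.2-fold lower number from compound 2 to compound 4 (0.71 log units; beyond the scatter) and stands clear of the other two groups, with a 3.0-fold lower number from compound 3 to compound 4 (0.47 log units; beyond the scatter) and a 2.3-fold lower number from compound 1 to compound 4 (0.36 log units; beyond the scatter) in this comparison. Having a hydroxy group is not enough by itself, since compound 3 also carries one, on its 4-hydroxybutyl, and only compound 4 separates from the rest. No measurement at hand accounts for this drop. From the compounds shown here alone, it stays open whether an isopropyl group, with no hydroxy, or a 1-aminoethyl group would give a similar number here.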